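A few compounds are considered here, and "the series" means these few. Any claim that something is new, unique, unknown or untested is made for them only; others in the source may bear on it.

Working notes on the series, read in a functional assay on the whole organism with Rattus norvegicus as the target; on this read-out lower numbers stand for an effect already at smaller amounts and higher numbers for an effect only at larger amounts of compound. Compound 1 `CCOC(=O)C(=O)Nc1nc(-c2ccc(O)cc2)cs1` gives about 15 mg/kg. Compound 2 `CCOC(=O)C(=O)Nc1nc(-c2ccc(Oc3ccccc3)cc2)cs1` gives > 30 mg/kg, which is a limit of the assay and not a number. Compound 3 `CCOC(=O)C(=O)Nc1nc(-c2ccc(NC(=O)C(F)(F)F)cc2)cs1` gives about 1 mg/kg, the lowest number of the three, and its steps to both others lie beyond the scatter.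

Compound 4 `CCCC(=O)Nc1ccc(-c2csc(NC(=O)C(=O)OCC)n2)cc1` follows from compound 3 with propyl in place of trifluoromethyl on a carbonyl carbon, the carbonyl carbon having an amide-type nitrogen as its other neighbour: propyl in place of trifluoromethyl on a carbonyl carbon.

Going by the values given here, no measured step changes the trifluoromethyl alone. The nearest evidence is a 15-fold lower number from compound 1 to compound 3 (1.18 log units; beyond the scatter) and an at least 30-fold lower number from compound 2 to compound 3 (1.47 log units; beyond the scatter), both large, and in both the whole ((trifluoromethyl)carbonyl)amino group is exchanged on an aromatic carbon. They show that this place can move the number widely in this assay, but they do not separate the amide from its trifluoromethyl. Compound 4 keeps the amide, so a change smaller than those two steps is expected. The direction is expected to be towards a higher number, given that compound 3 already sits lowest at about 1 mg/kg. The expected step is a 3.0-fold higher number from compound 3 to compound 4 (0.48 log units; beyond the scatter). For compound 4 the estimated value is 3 mg/kg, with an expected range from 0.8 mg/kg to 12 mg/kg.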

Compound 4, dose for half-maximal effect: > 10 mg/kg
Compound 4 ended at the assay's limit; the forecaster's own chance of this, stated with the estimate: 10%; middle value at least 3.3-fold (0.52 log units) away from the limit.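

With the amide kept, propyl in place of trifluoromethyl on the carbonyl carbon gives an at least 10-fold higher number from compound 3 to compound 4 (1.00 log units; beyond the scatter) in this assay, so the low number of compound 3 does not belong to the amide alone. The earlier steps shown here exchanged the whole ((trifluoromethyl)carbonyl)amino group on an aromatic carbon; this step shows that the group on the carbonyl carbon can by itself move the number beyond the scatter. For compound 4 the value is a limit of the assay and not a number, and the full size of the step remains unread: the limit of > 10 mg/kg in this assay, at which 1 of the 4 values shown sits.

The steps to compound 4 from compound 1 and from compound 2 cannot be read, which leaves (propylcarbonyl)amino unplaced against hydroxy and phenoxy. Also open, as far as these compounds go, is whether the low number of compound 3 depends on all the fluorine atoms or only on some of them, which a difluoromethyl or a methyl on the same carbonyl carbon would help to test, and how a free amine in place of the whole ((trifluoromethyl)carbonyl)amino group would read.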